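Carboxy to carbamoyl on a shared phenyl-ether core

A few compounds are considered here, and "the series" means these few. Any claim that something is new, unique, unknown or untested is made for them only; others in the source may bear on it.

Measured compounds:
compound 1, `C=C(CC)C(=O)c1ccc(OCC(=O)Nc2ccc3c(c2)C(=O)NC3=O)c(Cl)c1Cl`, 2500 nM
compound 2, `C=C(CC)C(=O)c1ccc(OCC(=O)Nc2ccc(C(=O)O)cc2)c(Cl)c1Cl`, 5000 nM
compound 3, `C=C(CC)C(=O)c1ccc(OCC(=O)Nc2nc(/C(=N\OC)C(=O)O)cs2)c(Cl)c1Cl`, > 25000 nM

In a functional assay on CLL cells (Homo sapiens) for cytotoxicity, read by MTT assay, with a stated time of 48 h (on this read-out lower numbers stand for an effect already at smaller amounts and higher numbers for an effect only at larger amounts of compound), compound 2 gives 5000 nM, the highest of the two numbers read, with compound 1 nearest at a step that lies within the scatter. For compound 3 this assay reports only a limit, (the limit of > 25000 nM in this assay, at which 1 of the 3 values shown sits). Compound 4, `C=C(CC)C(=O)c1ccc(OCC(=O)Nc2ccc(C(N)=O)cc2)c(Cl)c1Cl`, differs from compound 2 in one place: amino in place of hydroxy on a carbonyl carbon. Among the measured compounds shown here, no measured step of this kind is available, so the expectation for compound 4 rests on compound 2 alone; a small step toward a lower number, not clearly beyond the scatter, is expected, as a 1.4-fold lower number from compound 2 to compound 4 (0.15 log units; within the scatter). For compound 4 the estimated value in this assay is 3500 nM, expected between 1200 nM and 10000 nM.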

Compound 4, half-maximal effective concentration: 3700 nM
Compound 4: the middle estimate sits 1.1-fold (0.02 log units) below what was measured; measured number inside the range.
By their numbers in this assay, from the lowest: compounds 1, 4 and 2 (each within the scatter of the next). At a limit, above all of these: compound 3.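

In this assay, among the compounds shown here, amino in place of hydroxy on a carbonyl carbon gives a 1.4-fold lower number from compound 2 to compound 4 (0.13 log units; within the scatter) as the first step read between compounds that differ in one place. It shows that carboxy can give way to carbamoyl on this phenyl ring with no change beyond the scatter. Nothing in the data shown accounts for this step.

The compounds shown leave open whether methylamino or methoxy in place of hydroxy on the same carbonyl carbon would stay within the scatter of compound 2. As far as these compounds go, whether an amine replacing the whole carboxy group would do so also remains open.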